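The source may hold more compounds than are shown below. What is called first, only, known or untested is meant among the compounds shown, and "the series" means these compounds.

Three sulfated glycosides were measured in an assay on isolated protein for binding affinity to fibroblast growth factor 1 (Homo sapiens), read by surface plasmon resonance; a higher number here means weaker binding, a lower number tighter binding. Compound 1 `CCN(CC(=O)NC[C@H]1O[C@H](OC)[C@@H](OS(=O)(=O)O)[C@@H](OS(=O)(=O)O)[C@@H]1OS(=O)(=O)O)C(=O)COS(=O)(=O)O` gives 174000 nM in this assay, compound 2 `CCN(CC(=O)NC[C@H]1O[C@H](OC)[C@@H](OS(=O)(=O)O)[C@@H](OS(=O)(=O)O)[C@@H]1OS(=O)(=O)O)C(=O)CCCCCCCCCOS(=O)(=O)O` gives 111000 nM, and compound 3 `CO[C@H]1O[C@H](CNC(=O)CN(C(C)=O)C2CCCCC2)[C@@H](OS(=O)(=O)O)[C@H](OS(=O)(=O)O)[C@@H]1OS(=O)(=O)O` gives 310000 nM. Compound 2 thus holds the lowest of the three numbers; its gap to compound 1 lies within the scatter, while its gap to compound 3 lies beyond it. For the measured compounds named here, the one step between compounds that differ in a single place, a 1.8-fold higher number from compound 1 to compound 3 (0.25 log units; within the scatter), stays within the scatter.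

Compound 4 `CCN(CC(=O)NC[C@H]1O[C@H](OC)[C@@H](OS(=O)(=O)O)[C@@H](OS(=O)(=O)O)[C@@H]1OS(=O)(=O)O)C(=O)CCCCC(=O)O` arises from compound 2 by carboxy in place of 5-(sulfooxy)pentyl on a saturated chain carbon, four bonds along the chain from a carbonyl carbon. Going by the values given here, no measured step tests that change: the step from compound 1 to compound 3 alters the amide end and not the chain, and compounds 1 and 2, which carry a short and a long sulfooxy chain, sit within the scatter of each other. The sulfooxy group of the leaving chain is not carried over to compound 4, so a modest shift toward a higher number is expected rather than a clear gain. The step from compound 2 to compound 4 is therefore estimated at a 1.6-fold higher number from compound 2 to compound 4 (0.21 log units; within the scatter), and compound 4 is expected to give about 180000 nM in this assay, within a range from 90000 nM to 400000 nM.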

Compound 4, dissociation constant: 160000 nM
Estimate against measurement, compound 4: 1.1-fold (0.05 log units) above; the range from low to high includes it.
By their numbers in this assay, from the lowest: compounds 2, 4, 1 and 3 (each within the scatter of the next, the first and the last beyond it).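

In this assay, the chain end of compound 2 proves exchangeable: putting carboxy in place of 5-(sulfooxy)pentyl, on a saturated chain carbon four bonds along the chain from a carbonyl carbon, gives a 1.4-fold higher number from compound 2 to compound 4 (0.16 log units; within the scatter). For the compounds shown here, compound 4 also stays within the scatter of the short sulfooxy chain, with a 1.1-fold lower number from compound 1 to compound 4 (0.04 log units; within the scatter), and of the acetyl(cyclohexyl)amino compound, with a 1.9-fold lower number from compound 3 to compound 4 (0.29 log units; within the scatter), so a terminal sulfooxy group is not required on this chain for a number in this range, and the shorter carboxy-ended chain is the first end group here that carries no sulfur. No measurement is available that would explain this result.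

The compounds shown leave open whether an amine, a phosphate or a tetrazole at the end of this chain would also stay within the scatter, and whether a shorter or longer chain ending in a carboxylic acid would shift the number at all. They also leave open whether any change at this position can move the number beyond the scatter of compound 2.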